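Cytotoxicity notes on a dihydropyridinone series, compound 4

A few compounds are considered here, and "the series" means these few. Any claim that something is new, unique, unknown or untested is made for them only; others in the source may bear on it.

Measured so far in an ADME assay on BHK-21 cells (Mesocricetus auratus) for cytotoxicity, read by MTT assay, with a stated time of 48 h; on this read-out lower numbers stand for higher toxicity in this test and higher numbers for lower toxicity in this test:
- compound 1, `CC1(C)CC(=O)C2=C(C1)N(c1ccccc1)C(c1ccc(Br)cc1)N(c1ccccc1)C2`: > 20000 nM
- compound 2, `CC1(C)CC(=O)C2=C(C1)N(c1ccccc1)C(c1ccc(Br)cc1)N(c1ccc(F)cc1)C2`: 10000 nM
- compound 3, `CC1(C)CC(=O)C2=C(C1)N(c1ccccc1)C(c1ccc(Br)cc1)N(c1ccc(Cl)cc1)C2`: 12700 nM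

The value of compound 1 is a limit of this assay, not a number (the limit of > 20000 nM in this assay, at which 1 of the 3 values shown sits). Among the two actual numbers, compound 3 stands highest, with compound 2 nearest at a 1.3-fold higher number from compound 2 to compound 3 (0.10 log units; within the scatter), so these two are not distinguishable. The step of an at least 2.0-fold lower number from compound 1 to compound 2 (0.30 log units; that floor lies within the scatter) and the step of an at least 1.5-fold lower number from compound 1 to compound 3 (0.19 log units; that floor lies within the scatter) both run from the limit down to a number, and their stated floors also lie within the scatter.

Compound 4, `CC1(C)CC(=O)C2=C(C1)N(c1ccc(F)cc1)C(c1ccc(Br)cc1)N(c1ccc(Cl)cc1)C2`, differs from compound 3 by fluoro in place of hydrogen on an aromatic carbon. The nearest measured precedent is the fluoro for hydrogen change from compound 1 to compound 2, which gave an at least 2.0-fold lower number from compound 1 to compound 2 (0.30 log units; that floor lies within the scatter), but from a limit only. A step of similar direction and modest size is therefore expected for compound 4, a 1.4-fold lower number from compound 3 to compound 4 (0.15 log units; within the scatter), without confidence that it exceeds the scatter. Compound 4 is estimated at 9000 nM, with a range from 4000 nM to 20000 nM.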

Compound 4, half-maximal cytotoxic concentration: > 20000 nM
Compound 4: only a limit was reported; the forecaster's own chance of this, stated with the estimate: 15%; at least 2.2-fold (0.34 log units) between middle value and limit.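

In this assay, the phenyl to 4-fluorophenyl change, on an aromatic carbon para to a large group, gave an at least 1.5-fold higher number from compound 3 to compound 4 (0.19 log units; that floor lies within the scatter), so fluoro in place of hydrogen here did not bring the lower number that the earlier step suggested. The direction of this change therefore depends on the core that carries it, and the gap between the two steps is printed as beyond the scatter: the same change on two cores in this assay, an at least 2.0-fold lower number (0.30 log units; that floor lies within the scatter) from compound 1 to compound 2 and an at least 1.5-fold higher number (0.19 log units; that floor lies within the scatter) from compound 3 to compound 4, at least 3.1-fold (0.49 log units) apart, beyond the scatter of two such steps The value of compound 4 is a limit and not a number, as is the value of compound 1: the limit of > 20000 nM in this assay, at which 2 of the 4 values shown sit.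

As far as these compounds go, how far compound 4 and compound 1 lie beyond that limit remains open, so neither step has a known size. Also open, from the compounds shown here alone, is how the number responds to an amine, a carboxylic acid or a methoxy group on the same aromatic carbon.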